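The compounds below may be only part of what the source reports. "The series", "measured", "known", "first", "only" and "open" are said of these compounds alone.

Measured compounds in an assay for inhibition of Amine oxidase [flavin-containing] B (Rattus norvegicus); a higher number here means a weaker inhibitor, a lower number a stronger inhibitor:
compound 1 `N#CCCn1nc(-c2ccc(OCc3ccccc3)cc2)oc1=O`: 2.2 nM
compound 2 `N#CCCn1nc(-c2ccc(OCc3cccc(Cl)c3)cc2)oc1=O`: 12 nM
compound 3 `COc1ccc(COc2ccc(-c3nn(CCC#N)c(=S)o3)cc2)cc1`: 910 nM

Compound 3 gives the highest number of the three in this assay; the values of compound 1 and of compound 2 both lie far below it, beyond the scatter, so compound 3 is the weakest inhibitor measured here. Compound 4 `N#CCCn1nc(-c2ccc(OCc3ccc([N+](=O)[O-])cc3)cc2)oc1=S` is not yet measured. It differs from compound 3 by nitro in place of methoxy on an aromatic carbon.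

Among the compounds with values here, only one measured step touches the same benzyl ring: a 5.5-fold higher number from compound 1 to compound 2 (0.74 log units; beyond the scatter). That step replaces hydrogen by chloro rather than methoxy by nitro, and it was measured on compound 1 and compound 2, whose shared core is not that of compound 3 and compound 4. Within the data shown here, no measured pair exchanges methoxy for nitro, so the direction of the step from compound 3 to compound 4 is not fixed by the data. Among the measured compounds shown here, the one ring-substituent step seen was modest and went toward a higher number, so a step of similar modest size, more likely upward than downward, is expected in this assay, with a wide range to cover the unknown direction. Compound 4 is therefore estimated at 1500 nM, with a range of 300 nM to 7000 nM, which is expected to mean a 1.6-fold higher number from compound 3 to compound 4 (0.22 log units; within the scatter).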

Compound 4, half-maximal inhibitory concentration: 4300 nM
Compound 4: middle estimate off by 2.9-fold (0.46 log units), on the low side; low and high end bracket the measured number.
By their numbers in this assay, from the lowest: compound 1; then compound 2; then compound 3; then compound 4.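

In this assay, nitro in place of methoxy, on the aromatic carbon para to a large group, gives a 4.7-fold higher number from compound 3 to compound 4 (0.67 log units; beyond the scatter), so the number at this position on the core of compound 3 changes with the substituent, by more than the scatter. The earlier compounds shown here gave a ring-substituent step only on the core of compound 1, a 5.5-fold higher number from compound 1 to compound 2 (0.74 log units; beyond the scatter), with chloro in place of hydrogen; the new step also goes upward, but it has a different core and a different exchange, so the two steps establish no shared trend. Nothing at hand gives a measured reason for the new step.

The compounds shown do not set methoxy or nitro against hydrogen on the core of compound 3, so it remains open whether either group raises or lowers the number relative to the unsubstituted ring, and how an amine or a carboxylic acid at the same place would compare. From the compounds shown here alone, it also remains open whether the exchange of methoxy for nitro moves the number in the same direction and by a similar size on the core of compound 1.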